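Working notes: acetyl to ethoxycarbonyl on compound 3

This account rests on a few compounds, and the source may have more. Where it says the series, first, only, none or still open, it means among the compounds named here.

Measured in a functional assay on the whole organism for agonist activity, with Mus musculus as the target; on this read-out lower numbers stand for an effect already at smaller amounts and higher numbers for an effect only at larger amounts of compound:
compound 1 `CC(C#CCn1ccnc1)N1CCCC1=O` gives > 100 mg/kg (a limit of the assay)
compound 2 `CC(C#CCN(C)C)N1CCCC1=O` gives 6.6 mg/kg
compound 3 `CC(=O)N(C)CC#CCN1CCCC1` gives 0.55 mg/kg

For the measured compounds named here, compound 3 holds the lowest number so far at 0.55 mg/kg. Compound 2 stands higher at 6.6 mg/kg, a gap beyond the scatter. Compound 1 remains a limit at > 100 mg/kg.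

The unmeasured compound 4 `CCOC(=O)N(C)CC#CCN1CCCC1` differs from compound 3 at one place, with ethoxy in place of methyl on a carbonyl carbon, so acetyl becomes ethoxycarbonyl (ethoxy in place of methyl on a carbonyl carbon). Going by the values given here, no measured step touches that place. Among the compounds with values here, the only measured step, an at least 15-fold lower number from compound 1 to compound 2 (1.18 log units; beyond the scatter), concerns a different group and shows just that a single change can move this assay a long way. Compound 3 already sits lowest at 0.55 mg/kg, so a rise is expected rather than a fall, and a moderate one, smaller than that measured step. The expected change is an estimated 3.6-fold higher number from compound 3 to compound 4 (0.56 log units; beyond the scatter). For compound 4 the expected value is 2 mg/kg, with an estimated range of 0.5 mg/kg to 10 mg/kg.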

Compound 4, dose for half-maximal effect: > 100 mg/kg
Compound 4 was reported as a limit (the forecaster's own chance of this, stated with the estimate: 10%); at least 50-fold (1.69 log units) between middle value and limit.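

In this assay, the carbonyl carbon whose other neighbour is the amide-type nitrogen proves to be a sensitive place: ethoxy in place of methyl gives an at least 180-fold higher number from compound 3 to compound 4 (2.25 log units; beyond the scatter). For the compounds shown here, the only earlier step, an at least 15-fold lower number from compound 1 to compound 2 (1.18 log units; beyond the scatter), concerned a different place, so a large change is now seen at this carbonyl carbon too. The value of compound 4, > 100 mg/kg, is a limit of the assay and not a number, and it is a limit shared within the series: the limit of > 100 mg/kg in this assay, at which 2 of the 4 values shown sit.

The compounds shown do not separate the oxygen of ethoxy from its added carbons, and methoxy or ethyl on the same carbonyl carbon would tell these apart. They also leave open how an amine on that carbonyl carbon, or a longer chain than acetyl, would read out.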